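Swapping the isoxazole for a bromophenyl in a hydroxamate

The source may hold more compounds than are shown below. What is called first, only, known or untested is meant among the compounds shown, and "the series" means these compounds.

Within the data shown here, compound 1, `COc1ccc(S(=O)(=O)N(Cc2cc(C)on2)[C@H](C)C(=O)NO)cc1`, is the weakest of the three measured members of this hydroxamate series in an assay on isolated protein for inhibition of bone morphogenetic protein 1 (Homo sapiens) (a higher number here means a weaker inhibitor, a lower number a stronger inhibitor), where compound 1 gives 230 nM. Compound 3, `COc1ccc(S(=O)(=O)N(Cc2cc(C(F)(F)F)cc(C(F)(F)F)c2)[C@H](C)C(=O)NO)cc1`, sits within the usual scatter of that value, since in this assay compound 3 gives 220 nM. Compound 2, `COc1ccc(S(=O)(=O)N(Cc2ccccc2C(F)(F)F)[C@H](C)C(=O)NO)cc1`, stands well apart from both: in this assay compound 2 gives 6 nM, far below compound 1.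

Compound 4, `COc1ccc(S(=O)(=O)N(Cc2ccc(Br)cc2)[C@H](C)C(=O)NO)cc1`, has not been measured. It differs from compound 1 in one place: 4-bromophenyl in place of 5-methyl-1,2-oxazol-3-yl on a saturated chain carbon bound to a sulfonamide nitrogen. A heteroaromatic ring with acceptors thus gives way to a carbocyclic ring carrying a bromine.

Among the measured compounds shown here, no step between measured pairs is available, so the expectation rests on the spread of values. Compound 2 shows that a carbocyclic benzyl bearing a trifluoromethyl group can reach a low number, while compound 3 shows that not every substituted benzyl does. For compound 4 a step downward beyond the scatter is expected, a 3.8-fold lower number from compound 1 to compound 4 (0.58 log units; beyond the scatter), because compound 2 gives 6 nM and compound 3 gives 220 nM, and these two values bracket what benzyl groups have given here. Compound 4 is therefore estimated at 60 nM, with a plausible range from 15 nM to 250 nM.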

Compound 4, half-maximal inhibitory concentration: 37 nM
Estimate against measurement, compound 4: 1.6-fold (0.21 log units) above; low and high end bracket the measured number.
By their numbers in this assay, from the lowest: compound 2; then compound 4; then compounds 3 and 1 (each within the scatter of the next).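

In this assay, among these compounds, the exchange on the saturated chain carbon bound to a sulfonamide nitrogen gives the first step that can be read at this position, a 6.2-fold lower number from compound 1 to compound 4 (0.79 log units; beyond the scatter), as 4-bromophenyl takes the place of 5-methyl-1,2-oxazol-3-yl. The earlier compounds shown here differed from one another in more than one respect and could only mark out a spread of values, whereas this pair ties a change in the number to this one exchange on an otherwise unchanged core. It shows that the two hydrogen-bond acceptors of the leaving ring are not needed for a lower number here, as the entering six-membered ring of carbon only has none and its bromine comes with it; no data at hand account for the step.

From the compounds shown here alone, whether the lower number goes with the carbon ring or with the bromine remains open, and a plain phenyl ring at this place would separate the two. Equally open, going by these compounds, is how a pyridine ring, or a phenyl ring carrying an amine or a carboxylic acid, would read in this assay.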